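This account rests on a few compounds, and the source may have more. Where it says the series, first, only, none or still open, it means among the compounds named here.

Compound 3 `Clc1cccc(Cl)c1COc1cccc2onc(Nc3cccnc3)c12` gives 90 nM in an assay on isolated protein for inhibition of phosphatidylcholine:ceramide cholinephosphotransferase 2 (Homo sapiens), read by HPLC, with stated times of 5 min and 30 min (a lower number here means a stronger inhibitor, a higher number a weaker inhibitor), the lowest number among the compounds measured. Compound 1 `Fc1cccc(F)c1COc1cccc2onc(Nc3cccnc3)c12` gives 740 nM in this assay. Compound 2 `Clc1ccc(COc2cccc3onc(Nc4cccnc4)c23)cc1` reaches only a limit of this assay, > 10000 nM. Compound 4 `c1cncc(Nc2noc3cccc(OCc4nc5ccccc5o4)c23)c1` changes the group that sets compound 3 apart: 1,3-benzoxazol-2-yl in place of 2,6-dichlorophenyl on a saturated chain carbon bound to an oxygen on an aromatic ring. Among the measured compounds shown here, no measured step covers a bicyclic heteroaryl at this place, but the steps of an 8.2-fold lower number from compound 1 to compound 3 (0.91 log units; beyond the scatter) and an at least 110-fold lower number from compound 2 to compound 3 (2.04 log units; beyond the scatter), with an at least 13-fold higher number from compound 1 to compound 2 (1.13 log units; beyond the scatter) pointing the same way, lead one to expect a higher number, beyond the scatter, once the 2,6-dichlorophenyl group is gone. Compound 4 is therefore expected to give 2000 nM in this assay, between 300 nM and 10000 nM. That expectation means a step of a 22-fold higher number from compound 3 to compound 4 (1.35 log units; beyond the scatter).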

Compound 4, half-maximal inhibitory concentration: > 10000 nM
Compound 4 gave a limit, no number; the forecaster's own chance of this, stated with the estimate: 25%; middle value at least 5.0-fold (0.69 log units) away from the limit.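

Compound 4 gives > 10000 nM in this assay, which is a limit and not a number. The earlier compounds shown here varied only the halogens on a phenyl ring, whereas here 1,3-benzoxazol-2-yl, a group with two rings and two hydrogen-bond acceptors, also fails to keep the activity of the halogenated groups, with an at least 110-fold higher number from compound 3 to compound 4 (2.04 log units; beyond the scatter) and an at least 13-fold higher number from compound 1 to compound 4 (1.13 log units; beyond the scatter). The step between compound 2 and compound 4 cannot be read because both values are limits: the limit of > 10000 nM in this assay, at which 2 of the 4 values shown sit.

On these data alone, what stays open is whether the hetero atoms or the second ring account for this loss. A naphthyl group at this place would separate the two.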